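The compounds below may be only part of what the source reports. "The series", "measured", "known", "first", "only" and "open" are said of these compounds alone.

Measured so far in a functional assay on the whole organism with Mus musculus as the target, in the maximal electroshock model; on this read-out lower numbers stand for an effect already at smaller amounts and higher numbers for an effect only at larger amounts of compound:
Compound 1 `CC(=O)OC1CCN(c2ccc(-c3ccc(Cl)cc3Cl)nn2)CC1`: 14 mg/kg
Compound 2 `CCCC(=O)OC1CCN(c2ccc(-c3ccc(Cl)cc3Cl)nn2)CC1`: 50 mg/kg

Among the measured compounds shown here, compound 2 holds the higher of the two numbers, and compound 1 is its only measured neighbour. Compound 3 `CNC(=O)OC1CCN(c2ccc(-c3ccc(Cl)cc3Cl)nn2)CC1` departs from compound 2 by a single change, (methylamino in place of propyl on a carbonyl carbon), with methylamino in place of propyl on a carbonyl carbon. For the measured compounds named here, one measured step bears on this: a 3.6-fold higher number from compound 1 to compound 2 (0.55 log units; beyond the scatter), which came with ethyl in place of hydrogen on a saturated chain carbon bound to a carbonyl carbon. It was modest but beyond the scatter. Going by the values given here, no measured compound carries methylamino, so that group's own contribution is unknown. Going by a 3.6-fold higher number from compound 1 to compound 2 (0.55 log units; beyond the scatter), a modest move towards a lower number is expected in this assay, no larger than that measured step. The expected move is a 2.3-fold lower number from compound 2 to compound 3 (0.36 log units; beyond the scatter). For compound 3 the estimate is 22 mg/kg, with an expected range from 9 mg/kg to 55 mg/kg.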

Compound 3, dose for half-maximal effect: 5.5 mg/kg
The estimate for compound 3 lay 4.0-fold (0.60 log units) above the measured number; the measured number lies below the stated range.
By their numbers in this assay, from the lowest: compound 3; then compound 1; then compound 2.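

In this assay, the group on the carbonyl carbon proves able to move the number well below what the first two compounds showed. Methylamino in place of propyl gives a 9.1-fold lower number from compound 2 to compound 3 (0.96 log units; beyond the scatter), and methylamino in place of methyl still gives a 2.5-fold lower number from compound 1 to compound 3 (0.41 log units; beyond the scatter), so the lowest number does not belong to the smallest group: methylamino, with its two heavy atoms, falls in size between methyl and propyl, and the numbers do not follow that size order. Nothing available explains why this change lowers the number.

Going by these compounds, it remains open whether the lower number would persist with dimethylamino, which has no amide hydrogen, or with ethylamino, which has a longer chain. An unsubstituted amino group on the same carbonyl carbon is equally untested among the compounds shown.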